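The source may hold more compounds than are shown below. What is called first, only, known or untested is meant among the compounds shown, and "the series" means these compounds.

Compound 1 `COc1cccc(/C=C/c2cc3c(c(=O)n(C)c(=O)n3C)n2C)c1` carries a 3-methoxyphenyl on the double-bonded chain carbon, and in an assay on isolated protein for inhibition of Amine oxidase [flavin-containing] B (Homo sapiens), read by luminescence, with a stated time of 1 h (on this read-out higher numbers stand for weaker inhibition and lower numbers for stronger inhibition), compound 1 gives 370 nM. Compound 2 `Cn1c(=O)c2c(cc(/C=C/c3cccc(N)n3)n2C)n(C)c1=O` has a 6-aminopyridin-2-yl in that place. In this assay compound 2 returns only a limit, > 10000 nM, not a number. This is the limit of > 10000 nM in this assay, at which 1 of the 2 values shown sits. Going by the values given here, the single measured step, an at least 27-fold higher number from compound 1 to compound 2 (1.43 log units; beyond the scatter), therefore puts the aminopyridinyl analogue well off the methoxyphenyl one. Compound 3 `Cn1c(=O)c2c(cc(/C=C/c3cccc(C#N)c3)n2C)n(C)c1=O` is the next member: 3-cyanophenyl in place of 6-aminopyridin-2-yl on a double-bonded chain carbon bound to a double-bonded chain carbon. The change brings back a carbon-only six-membered aromatic ring with one hydrogen-bond acceptor and no donor, as in compound 1, so the direction of the measured step is expected to reverse. For compound 3 the step is expected to be an at least 20-fold lower number from compound 2 to compound 3 (1.30 log units; beyond the scatter), a large fall in the number. Compound 3 is accordingly estimated at 500 nM in this assay, with a range from 100 nM to 5000 nM.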

Compound 3, half-maximal inhibitory concentration: > 10000 nM
Compound 3 ended at the assay's limit; the forecaster's own chance of this, stated with the estimate: 10%; middle value at least 20-fold (1.30 log units) from the limit.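

Compound 3 shows that the carbon-only aromatic ring of compound 1 is not enough on its own to keep a readable number: in this assay, cyano in place of methoxy on an aromatic carbon gives an at least 27-fold higher number from compound 1 to compound 3 (1.43 log units; beyond the scatter). The loss seen with compound 2 therefore does not depend on a ring nitrogen or an amino group, as a change of the substituent alone on the carbon-only ring has a large effect. The step from compound 2 to compound 3 cannot be read, and the two compounds cannot be ordered, as neither gives a number, only a limit: the limit of > 10000 nM in this assay, at which 2 of the 3 values shown sit.

Among the compounds shown, only the methoxy group gives a number, so it remains open whether that result is specific to methoxy. An ethoxy, a hydroxyl or a chlorine in its place could separate these possibilities.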